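A few compounds are considered here, and "the series" means these few. Any claim that something is new, unique, unknown or untested is made for them only; others in the source may bear on it.

Measured compounds:
Compound 1 `CC(C)(O)CNc1c(-c2ccccn2)nc2ccccn12`; in an ADME assay on THP-1 cells (Homo sapiens) for cytotoxicity (a lower number here means that less compound is tolerated, a higher number that more compound is tolerated), compound 1 gives > 50000 nM, which is a limit of the assay and not a number.
Compound 2 `c1ccc(-c2nc3ccccn3c2NCC2CCO2)nc1`; in this assay compound 2 gives > 50000 nM, again a limit rather than a number.

Compound 2 therefore stands at the upper edge of what this assay reports, as does everything measured so far: the limit of > 50000 nM in this assay, at which 2 of the 2 values shown sit. For the measured compounds named here, the one measured step, a step that the two limits leave unreadable from compound 1 to compound 2, cannot be read for size or direction, since both of its ends are limits.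

Compound 3 `c1ccc(-c2nc3ccccn3c2NC2CCNC2)nc1` takes the step (pyrrolidin-3-yl in place of (oxetan-2-yl)methyl on a nitrogen on an aromatic ring). Going by the values given here, no readable measured step bears on this change; the only comparison available is the unreadable one just given. With both measured compounds tolerated up to the limit, compound 3 is expected to behave alike, and the step that the limit leaves unreadable from compound 2 to compound 3 is expected to be none beyond the scatter. Compound 3 is estimated at 60000 nM, within 20000 nM to 200000 nM, with the assay most likely again reporting only a limit.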

Compound 3, half-maximal cytotoxic concentration: > 50000 nM
Compound 3: only a limit was reported (the forecaster's own chance of this, stated with the estimate: 80%); the middle value does not contradict the limit.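

No new step can be read among compound 1, compound 2 and compound 3, since all three end in a limit of this assay and not a number: the limit of > 50000 nM in this assay, at which 3 of the 3 values shown sit.

The compounds shown leave open how far their cytotoxicity differs, and whether any substituent on this nitrogen gives a readable value.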